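Butyl on the ring carbon of compound 1

The compounds below may be only part of what the source reports. "The series", "measured", "known", "first", "only" and "open" are said of these compounds alone.

Measured compounds:
compound 1 `Cc1nccc2nn(-c3ccccc3)cc12`: > 100000 nM
compound 2 `c1ccc(-c2cc3nn(-c4ccccc4)cc3cn2)cc1`: 3400 nM
compound 3 `Cn1cc2cnc(-c3ccccc3)cc2n1`: > 100000 nM

In a functional assay on K562 cells (Homo sapiens) for inhibition, read by fluorescence, with a stated time of 72 h (a higher number here means a weaker inhibitor of growth, a lower number a stronger inhibitor of growth), compound 1 gives only a limit, > 100000 nM. Compound 3 also sits at a limit, > 100000 nM. Compound 2, which carries phenyl on the ring carbon and phenyl on the aromatic nitrogen, gives 3400 nM. Among the measured compounds shown here, the single measured step, an at least 29-fold higher number from compound 2 to compound 3 (1.46 log units; beyond the scatter), concerns the group on the aromatic nitrogen and leaves the ring carbon untouched, so it bears only indirectly on the change considered here. Two of the three values sit at the limit of > 100000 nM in this assay, at which 2 of the 3 values shown sit, so compound 1 cannot be placed more precisely than that.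

Compound 4 `CCCCc1cc2nn(-c3ccccc3)cc2c(C)n1` differs from compound 1 by butyl in place of hydrogen on an aromatic carbon. For the measured compounds named here, no measured step covers this change. Compound 2 shows that a substituent on the ring carbon, combined with phenyl on the aromatic nitrogen, can give a measurable number, but that substituent is phenyl, not butyl, and compound 2 lacks the methyl present in compound 1. The expectation is therefore a move toward a lower number of uncertain size, an at least 3.3-fold lower number from compound 1 to compound 4 (0.52 log units; beyond the scatter), with a real chance that only a limit is returned. For compound 4 the estimated value is 30000 nM, within a range of 5000 nM to 100000 nM.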

Compound 4, concentration for 50% growth inhibition: 8500 nM
Beside the measured number, compound 4's estimate is 3.5-fold (0.55 log units) above it, within the range that was stated.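

In this assay, butyl in place of hydrogen on an aromatic carbon, next to the ring nitrogen, gives an at least 11-fold lower number from compound 1 to compound 4 (1.07 log units; beyond the scatter), with the methyl group and the phenyl on the aromatic nitrogen unchanged. Among the compounds shown here, this is the first step that can be read at this position, and it shows that the position responds to substitution on the core of compound 1. A measurable number here does not depend on an aromatic substituent, as the butyl of compound 4 is a chain with no ring. The size of the step is only a bound, because compound 1 stands at a limit rather than at a number: the limit of > 100000 nM in this assay, at which 2 of the 4 values shown sit.

The compounds shown contain no pair that sets butyl against phenyl at this position with all else equal, so neither that comparison nor the part played by the methyl group can be read. Also open, from the compounds shown here alone, are how a longer chain such as hexyl, a shorter one such as ethyl, or a chain ending in an amine or a carboxylic acid would read here, and whether the gain from butyl would hold with methyl in place of phenyl on the aromatic nitrogen.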